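Removing the fluoro from compound 2 in the chloro series

This account rests on a few compounds, and the source may have more. Where it says the series, first, only, none or still open, it means among the compounds named here.

Of the compounds shown here, three have been measured in a functional assay on P815 cells (Mus musculus) for antiproliferative activity; on this read-out lower numbers stand for stronger inhibition and higher numbers for weaker inhibition. Compound 1 `Nc1ccn(C2OC(CO)C(Br)C2O)c(=O)n1` gives 0.05 ug/mL. Compound 2 `Nc1nc(=O)n(C2OC(CO)C(Cl)C2O)cc1F` gives 0.7 ug/mL, which is the highest of the three numbers recorded so far; its nearest neighbour is compound 3 `Nc1nc(=O)n(C2OC(CO)C(Br)C2O)cc1F`, which gives 0.2 ug/mL, and compound 1 lies furthest from it. The two single changes measured so far are a 4.0-fold higher number from compound 1 to compound 3 (0.60 log units; beyond the scatter) and a 3.5-fold lower number from compound 2 to compound 3 (0.54 log units; beyond the scatter).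

Compound 4 `Nc1ccn(C2OC(CO)C(Cl)C2O)c(=O)n1` is not yet measured. It differs from compound 2 in one place: hydrogen in place of fluoro on an aromatic carbon.

Going by the values given here, the step that bears on this change is the one in the bromo pair, a 4.0-fold higher number from compound 1 to compound 3 (0.60 log units; beyond the scatter), where the same exchange is seen in the opposite direction. Among the compounds with values here, no second pair with this exchange exists, so the transfer from the bromo to the chloro series rests on that one step alone. Compound 4 is therefore expected to give a lower number than compound 2, of a size comparable to the bromo pair, a 3.9-fold lower number from compound 2 to compound 4 (0.59 log units; beyond the scatter). The estimate for compound 4 is 0.18 ug/mL, with a range from 0.08 ug/mL to 0.4 ug/mL.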

Compound 4, concentration for 50% inhibition: 0.8 ug/mL
Estimate against measurement, compound 4: 4.4-fold (0.65 log units) below; the whole stated range lies below it.
By their numbers in this assay, from the lowest: compound 1; then compound 3; then compounds 2 and 4 (each within the scatter of the next).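

In this assay, hydrogen in place of fluoro on the aromatic carbon, ortho to the amino group, gives a 1.1-fold higher number from compound 2 to compound 4 (0.06 log units; within the scatter), so in the chloro series this exchange has no effect that can be read at this position. The bromo pair had suggested a clear effect of the same exchange, and the new step shows that the result at this position depends on which halogen sits on the saturated ring carbon: the same change on two cores in this assay, a 4.0-fold higher number (0.60 log units; beyond the scatter) from compound 1 to compound 3 and a 1.1-fold lower number (0.06 log units; within the scatter) from compound 4 to compound 2, 4.6-fold (0.66 log units) apart, beyond the scatter of two such steps. With hydrogen on the aromatic carbon, chloro in place of bromo on the saturated ring carbon gives a 16-fold higher number from compound 1 to compound 4 (1.20 log units; beyond the scatter), and this halogen exchange in turn costs more without the fluoro than with it: the same change on two cores in this assay, a 3.5-fold lower number (0.54 log units; beyond the scatter) from compound 2 to compound 3 and a 16-fold lower number (1.20 log units; beyond the scatter) from compound 4 to compound 1, 4.6-fold (0.66 log units) apart, beyond the scatter of two such steps.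

The compounds shown leave open whether a methyl group on the aromatic carbon would behave as in the bromo pair or as in the chloro pair. Going by these compounds alone, they also leave open whether iodo on the saturated ring carbon would continue the trend from chloro to bromo, and with only two pairs the dependence between the two positions rests on these four compounds alone.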